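Sulfonamide aryl substituent: fluoro enters compound 4

The source may report more compounds than this note shows. Statements on the series, on what has been measured and on what is new or still open speak of the compounds shown alone.

Compound 3 `O=C(NCc1ccc(CNS(=O)(=O)c2ccccc2)cc1)c1ccc(CNc2ncccn2)cc1` is assessed in an assay on MDA-MB-231 cells for binding affinity to C-X-C chemokine receptor type 4 (Homo sapiens), read by microscopy, with stated times of 10 min and 30 min (on this read-out lower numbers stand for an effect already at smaller amounts and higher numbers for an effect only at larger amounts of compound), where compound 3 gives 1 nM. Compound 2 `O=C(NCc1ccc(CNS(=O)(=O)c2cccc(Cl)c2)cc1)c1ccc(CNc2ncccn2)cc1` gives 1 nM, so no change at the digits printed from compound 2 to compound 3 (within the scatter). Compound 1 `Cc1cccc(S(=O)(=O)NCc2ccc(CNC(=O)c3ccc(CNc4ncccn4)cc3)cc2)c1` gives 100 nM; from there a 100-fold lower number from compound 1 to compound 3 (2.00 log units; beyond the scatter) and a 100-fold lower number from compound 1 to compound 2 (2.00 log units; beyond the scatter). Compound 3 therefore stands, together with compound 2, at the lowest of the three numbers. Compound 4 `O=C(NCc1ccc(CNS(=O)(=O)c2ccccc2F)cc1)c1ccc(CNc2ncccn2)cc1` differs from compound 3 in one place: fluoro in place of hydrogen on an aromatic carbon. The measured steps bearing on this site are mixed: one exchange of a small aromatic substituent left the number unchanged, another moved it a long way. A fluoro entering is a small change of the same kind, and for compound 4 a step of a 1.5-fold higher number from compound 3 to compound 4 (0.18 log units; within the scatter) is expected, within the scatter. Compound 4 is estimated at 1.5 nM, between 0.5 nM and 10 nM.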

Compound 4, effective concentration (reported as EC, without a stated level of effect): 1000 nM
The estimate for compound 4 lay 670-fold (2.82 log units) below the measured number; measured number above the stated range.
By their numbers in this assay, from the lowest: compounds 2 and 3 (each within the scatter of the next); then compound 1; then compound 4.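

In this assay, the sulfonyl aryl ring proves sensitive to a single added heavy atom: a fluoro ortho to a large group gives a 1000-fold higher number from compound 3 to compound 4 (3.00 log units; beyond the scatter). The exchange of 3-chlorophenyl for 2-fluorophenyl gives a step of the same size, a 1000-fold higher number from compound 2 to compound 4 (3.00 log units; beyond the scatter), whereas the earlier exchange of chloro for hydrogen at the other ring carbon left the number unchanged. Even against the 3-methylphenyl compound there is a 10-fold higher number from compound 1 to compound 4 (1.00 log units; beyond the scatter), and nothing at hand accounts for these steps.

Going by these compounds, whether the rise follows the fluoro itself or its place on the ring stays open. Also open, on these data alone, is how a methoxy or an amine on the same carbon would read.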